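Cytotoxicity notes on a biaryl amide series

The compounds below may be only part of what the source reports. "The series", "measured", "known", "first", "only" and "open" are said of these compounds alone.

Compound 1 `CC(=O)c1cccc(-c2ccc(C(=O)N(Cc3cccc(OCCCCCC(=O)O)c3)C(C)C)cc2)c1` and compound 2 `CCOC(=O)CCCCCOc1cccc(CN(C(=O)c2ccc(-c3cccc(NC(C)=O)c3)cc2)C(C)C)c1` share one core and differ in two places, the chain end and the group on the outer ring. In an ADME assay on HepG2 cells (Homo sapiens) for cytotoxicity, read by CellTiter-Glo and resazurin assay, with a stated time of 72 h (on this read-out higher numbers stand for an effect only at larger amounts of compound and lower numbers for an effect already at smaller amounts), compound 1 gives > 26000 nM, which is a limit of the assay and not a number. In this assay compound 2 likewise gives > 26000 nM, again a limit rather than a measured number. For the measured compounds named here, compound 2 thus stands at the limit of this assay, as does the one further value shown, so that the limit of > 26000 nM in this assay, at which 2 of the 2 values shown sit, covers both. Going by the values given here, no step between measured compounds is available, and nothing separates compound 1 from compound 2 on these numbers.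

Compound 3 `CCOC(=O)CCCCCOc1cccc(CN(C(=O)c2ccc(-c3cccc(C(C)=O)c3)cc2)C(C)C)c1` is not yet measured in this assay. It differs from compound 2 in one place: acetyl in place of acetamido on an aromatic carbon. Acetyl on an aromatic carbon is also present in compound 1, which sits at the same limit.

For compound 3 in this assay no effect within the tested range is expected, and the step that the limit leaves unreadable from compound 2 to compound 3 is expected to be none beyond the scatter. The estimate for compound 3 is 30000 nM, with a range from 15000 nM to 60000 nM, most likely reported as a limit again.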

Compound 3, half-maximal effective concentration: > 26000 nM
Compound 3 ended at the assay's limit; the forecaster's own chance of this, stated with the estimate: 85%; the middle value does not contradict the limit.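

No step can be read from compound 2 to compound 3 or from compound 1 to compound 3, since compound 1, compound 2 and compound 3 all stand at one limit of the assay, which is not a number: the limit of > 26000 nM in this assay, at which 3 of the 3 values shown sit.

The compounds shown leave open whether any structure in this series gives a measurable effect in this assay, and whether either change alters it.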